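The source may report more compounds than this note shows. Statements on the series, on what has been measured and on what is new or still open speak of the compounds shown alone.

Compound 1 `O=C(CCC1=CCN(CCCc2ccc(Cl)cc2)C1=O)NO`: 3480 nM
Compound 2 `O=C(CCC1=CCN(Cc2ccc(F)cc2)C1=O)NO`: 5310 nM
Compound 3 `Cc1ccc(CCCCN2CC=C(CCC(=O)NO)C2=O)cc1`: 6090 nM

All three were tested in a functional assay on PC-3 cells (Homo sapiens) for inhibition, read by sulforhodamine B assay; on this read-out lower numbers stand for stronger inhibition of growth and higher numbers for weaker inhibition of growth. Compound 2 sits second highest of the three numbers; its nearest neighbour is compound 3 and its furthest is compound 1, and both gaps lie within the scatter of repeated measurements, so no ranking among them can be claimed. Compound 4 `O=C(CCC1=CCN(Cc2ccc(Cl)cc2)C1=O)NO` has not been measured. It differs from compound 2 in one place: chloro in place of fluoro on an aromatic carbon. Among the measured compounds shown here, no measured pair shows this particular change, so no step of this kind is known from the data. The swap exchanges one heavy atom for one heavy atom. No step beyond the scatter is expected in this assay in either direction. Compound 4 is therefore estimated at 4500 nM, with a range from 1500 nM to 13000 nM. The expected step of a 1.2-fold lower number from compound 2 to compound 4 (0.07 log units; within the scatter) is thus roughly flat.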

Compound 4, concentration for 50% growth inhibition: 4620 nM
For compound 4 the middle estimate is 1.0-fold (0.01 log units) below the measured one; measured number inside the range.
By their numbers in this assay, from the lowest: compounds 1, 4, 2 and 3 (each within the scatter of the next).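

In this assay, among the compounds shown here, chloro in place of fluoro on the aromatic carbon para to a large group gives a 1.1-fold lower number from compound 2 to compound 4 (0.06 log units; within the scatter) and provides the first step between compounds that differ in one place. At this position, then, swapping one of these atoms for the other leaves the number within the usual scatter. No measurement shown here offers an explanation for this result. Still open, on these data alone, is whether a very different group at the same position, such as an amine or a carboxylic acid, would give a step beyond the scatter.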